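The compounds below may be only part of what the source reports. "The series", "measured", "known", "first", "only" and "open" are said of these compounds alone.

Measured in a functional assay on HCT-116 cells (Homo sapiens); a higher number here means a weaker inhibitor of growth, a lower number a stronger inhibitor of growth:
- Compound 1 `COc1cccc(-c2cc(O)c3cc(C)cnc3n2)c1`: 22.4 nM
- Compound 2 `COc1cccc(-c2cc(O)c3c(C)ccnc3n2)c1`: 44.7 nM

Compound 2, at 44.7 nM, stands within the scatter of compound 1, so the two numbers cannot be told apart. Compound 3 `COc1cccc(-c2cc(O)c3cccnc3n2)c1` follows from compound 2 through one change, hydrogen in place of methyl on an aromatic carbon. Among the compounds with values here, no measured pair shows this change, so any expectation is loose. An estimated step of a 1.6-fold higher number from compound 2 to compound 3 (0.19 log units; within the scatter) is expected in this assay, towards a somewhat higher number and not clearly beyond the scatter. Compound 3 is expected at 70 nM, within an estimated range of 22 nM to 220 nM.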

Compound 3, concentration for 50% growth inhibition: 36.3 nM
Beside the measured number, compound 3's estimate is 1.9-fold (0.29 log units) above it, and the stated range covers the measured number.
By their numbers in this assay, from the lowest: compounds 1, 3 and 2 (each within the scatter of the next).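

In this assay hydrogen in place of methyl on an aromatic carbon gives a 1.2-fold lower number from compound 2 to compound 3 (0.09 log units; within the scatter) and, at the other methyl position, a 1.6-fold higher number from compound 1 to compound 3 (0.21 log units; within the scatter) as well. Both steps stay within the scatter, so neither methyl, including the one opposite the ring nitrogen, can be told from hydrogen on these numbers. Nothing at hand bears on why this is so.

As far as these compounds go, whether a larger group, such as a longer chain or an amine, would be tolerated at these positions stays open. So does the effect of a chlorine atom there.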